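Swapping the halogenated phenyl arm of compound 2

This account rests on a few compounds, and the source may have more. Where it says the series, first, only, none or still open, it means among the compounds named here.

Of the compounds shown here, three have been tested in a functional assay on U-937 cells (Homo sapiens) for cytotoxicity, read by CCK-8 assay, with a stated time of 72 h; on this read-out higher numbers stand for weaker inhibition and lower numbers for stronger inhibition. Compound 1 `COc1ccccc1/C=c1/[nH]c(=O)/c(=C\c2ccccc2OC)[nH]c1=O` is reported as "not active" (no number reported) in this assay, with no number attached. Compound 3 `C=CCn1c(=O)/c(=C\c2cc(OC)c(OC)c(OC)c2)[nH]c(=O)/c1=C\c1cccc(Br)c1` is likewise reported as "not active" (no number reported) in this assay. Compound 2 `C=CCn1c(=O)/c(=C\c2cccc(F)c2)[nH]c(=O)/c1=C\c1ccccc1OC` is the only one of the three that yields a number: in this assay compound 2 gives 2500 nM. Compound 2 therefore stands alone on the numbers shown, and no step between measured compounds can be sized from them.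

Compound 4 `C=CCn1c(=O)/c(=C\c2ccccc2Cl)[nH]c(=O)/c1=C\c1ccccc1OC` differs from compound 2 in one place: 2-chlorophenyl in place of 3-fluorophenyl on a double-bonded chain carbon bound to an aromatic carbon. The remainder of the molecule, including the allyl group and the shared core, is unchanged.

Among the compounds with values here, since no measured step of this kind is available, the step is expected to be small, roughly within or just beyond the usual scatter, leaning weaker. Compound 4 is estimated at 3500 nM, with a likely range from 1200 nM to 12000 nM. This means an expected step of a 1.4-fold higher number from compound 2 to compound 4 (0.15 log units; within the scatter).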

Compound 4, half-maximal inhibitory concentration: 700 nM
Compound 4: middle estimate off by 5.0-fold (0.70 log units), on the high side; the measured number lies below the stated range.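

At the double-bonded chain carbon bound to an aromatic carbon, the choice of aryl arm alone moves the result in this assay: 2-chlorophenyl in place of 3-fluorophenyl gives a 3.6-fold lower number from compound 2 to compound 4 (0.55 log units; beyond the scatter), with the allyl group and the shared core unchanged. Within the data shown here, this is the first sized step, and it shows stronger inhibition rather than the near-neutral change that a swap between two halogenated phenyl groups might suggest, while no step to compound 1 or compound 3 can be read. Nothing measured here accounts for the gain.

The swap changes both the halogen and its place on the phenyl ring, so this single pair cannot separate the two changes. A 2-fluorophenyl or 3-chlorophenyl arm would tell them apart, and a 2-aminophenyl arm would test whether a halogen is needed at all.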